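The compounds below may be only part of what the source reports. "The series", "measured", "known", "first", "only" and "open" are said of these compounds alone.

Of the compounds shown here, three have been measured in a functional assay on LS174T cells (Homo sapiens) for inhibition, with a stated time of 4 days, tested at 10 uM; a lower number here means a weaker effect, a higher number a stronger effect of the compound at the concentration tested. Compound 1 `CN(C)c1ccc2cc(C#Cc3c(F)cccc3F)ccc2n1` gives 38.7% in this assay. Compound 2 `Cn1ccc2cc(C#Cc3c(F)cccc3F)ccc21` gives 95.2%. Compound 3 `Fc1cccc(F)c1C#Cc1cncc2ccccc12` gives 87.9%, the second highest of the three numbers; its nearest neighbour is compound 2, within the scatter, and its furthest is compound 1, beyond the scatter. Compound 4 `Fc1cccc(F)c1C#Cc1cnc(Cl)c2ccccc12` differs from compound 3 by chloro in place of hydrogen on an aromatic carbon. No pair of measured compounds isolates this change, so its effect cannot be read from the numbers shown. Compound 4 is expected to give about 80%, with a range from 45% to 98%. The estimated step is a number 7.9 percentage points lower from compound 3 to compound 4 (within the scatter), expected to lie within the scatter.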

Compound 4, a percentage reported as inhibition, at one concentration (the size of the read-out at that concentration, not a potency): 94%
Compound 4: middle estimate off by 14 percentage points, on the low side, and the stated range covers the measured number.
By their numbers in this assay, from the lowest: compound 1; then compounds 3, 4 and 2 (each within the scatter of the next).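

In this assay, chloro in place of hydrogen on the aromatic carbon next to the ring nitrogen gives a number 6.1 percentage points higher from compound 3 to compound 4 (within the scatter). This is the first substituent shown at this place, and it shows that the place accepts a chloro with the effect remaining within the scatter. Nothing available explains this result. On these data alone, whether an amine, a methoxy group or a nitrile at this place would keep the effect remains open. A read-out at one concentration also cannot tell whether compound 3 and compound 4 differ in potency.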